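Series notes: from compound 2 to compound 3

The source may hold more compounds than are shown below. What is called first, only, known or untested is meant among the compounds shown, and "the series" means these compounds.

Compound 1 `C=CCNC(=S)NC1=C(C#N)C(c2ccc(Cl)cc2Cl)C2=C(CCCC2=O)N1c1ccc(S(N)(=O)=O)cc1` gives 10% in a functional assay on Ehrlich cells (Mus musculus) for cytotoxicity, read by trypan blue exclusion, with a stated time of 2 h, tested at 10 ug/mL; a lower number here means a weaker effect, a higher number a stronger effect of the compound at the concentration tested. Among the measured compounds shown here, compound 2 `N#CC1=C(NC(=S)Nc2ccc(Cl)cc2)N(c2ccc(S(N)(=O)=O)cc2)C2=C(C(=O)CCC2)C1c1ccc(Cl)cc1Cl` gives 30% in this assay, the higher of the two numbers measured so far; the step of a number 20 percentage points higher from compound 1 to compound 2 (beyond the scatter) is the only measured step in the set, and it sits on the same nitrogen that changes next. Compound 3 `N#CC1=C(NS(=O)(=O)c2ccc([N+](=O)[O-])cc2)N(c2ccc(S(N)(=O)=O)cc2)C2=C(C(=O)CCC2)C1c1ccc(Cl)cc1Cl` is not yet measured. Relative to compound 2 it carries a group of 12 heavy atoms (6 carbon, 1 nitrogen, 4 oxygen, 1 sulfur; one six-membered aromatic ring of carbon only) in place of a group of 10 heavy atoms (7 carbon, 1 nitrogen, 1 sulfur, 1 chlorine; one six-membered aromatic ring of carbon only), on an amine nitrogen. For the measured compounds named here, the one measured step bears on the expectation only loosely: it shows that exchanging the group on this nitrogen, allyl for 4-chlorophenyl, moved the read-out modestly, but no measured pair exchanges 4-chlorophenyl for (4-nitrophenyl)sulfonyl, so the direction for compound 3 cannot be read from the data. The step of a number 5 percentage points lower from compound 2 to compound 3 (within the scatter) is expected to remain small, quite possibly within the scatter, with no firm direction. Compound 3 is estimated at 25%, with a range from 5% to 50%.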

Compound 3, a percentage reported as activity, at one concentration (the size of the read-out at that concentration, not a potency): 50%
For compound 3 the middle estimate is 25 percentage points below the measured one; measured number inside the range.
By their numbers in this assay, from the lowest: compound 1; then compound 2; then compound 3.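

Placing (4-nitrophenyl)sulfonyl on the amine nitrogen gives a number 20 percentage points higher from compound 2 to compound 3 (beyond the scatter) in this assay, so the read-out at this position is not capped by the 4-chlorophenyl-bearing group that led among the earlier compounds. Measured against the allyl-bearing group, the same exchange gives a number 40 percentage points higher from compound 1 to compound 3 (beyond the scatter), the largest step in the set, and it places compound 3 highest of the three, with both of its steps beyond the scatter. Nothing available explains why this group raises the read-out.

The exchange alters the link to the nitrogen and the substituent on the aromatic ring together, so the compounds shown cannot separate the contribution of the sulfonyl link from that of the nitro group; phenylsulfonyl and (4-chlorophenyl)sulfonyl on the same nitrogen would separate them. Also open, going by these compounds, is whether the aromatic ring is needed at all, as methylsulfonyl would show, and, with every number taken at a single concentration, how the three compounds rank in potency.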